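A New Group on the Sulfonyl Sulfur

A few compounds are considered here, and "the series" means these few. Any claim that something is new, unique, unknown or untested is made for them only; others in the source may bear on it.

- Compound 1 `O=S(=O)(c1ccccc1)n1c(-c2cn(-c3ccccc3)nc2-c2ccc(F)cc2)nc2ccccc21` gives 680 nM
- Compound 2 `COc1ccc(S(=O)(=O)n2c(-c3cn(-c4ccccc4)nc3-c3ccc(F)cc3)nc3ccccc32)cc1` gives 390 nM

Both numbers come from a functional assay on HeLa cells (Homo sapiens) for antiproliferative activity, read by MTT assay, with a stated time of 24 h; on this read-out higher numbers stand for weaker inhibition and lower numbers for stronger inhibition. They lie within the usual scatter of each other, so compound 2 stands level with compound 1 and neither can be ranked ahead.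

Compound 3 `Cc1ccc(C)c(S(=O)(=O)n2c(-c3cn(-c4ccccc4)nc3-c3ccc(F)cc3)nc3ccccc32)c1` has not yet been measured. It differs from compound 2 in one place: 2,5-dimethylphenyl in place of 4-methoxyphenyl on a sulfonyl sulfur. In words, it carries 2,5-dimethylphenyl in place of 4-methoxyphenyl on a sulfonyl sulfur.

Among the compounds with values here, only one measured step bears on this group: a 1.7-fold lower number from compound 1 to compound 2 (0.24 log units; within the scatter), with methoxy in place of hydrogen on an aromatic carbon. Within the data shown here, that step is a limited guide, since no compound with 2,5-dimethylphenyl has been measured. Still, it gives no sign that this group moves the number much, so no step beyond the scatter is expected in this assay, in either direction.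

The expected step is a 1.2-fold higher number from compound 2 to compound 3 (0.06 log units; within the scatter). For compound 3 the estimated value is 450 nM, with an expected range from 200 nM to 1000 nM.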

Compound 3, half-maximal inhibitory concentration: 320 nM
Estimate against measurement, compound 3: 1.4-fold (0.15 log units) above, and the stated range covers the measured number.
By their numbers in this assay, from the lowest: compounds 3, 2 and 1 (each within the scatter of the next, the first and the last beyond it).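

In this assay, the group on the sulfonyl sulfur need not carry oxygen to keep this level of activity: 4-methoxyphenyl, with 1 hydrogen-bond acceptor, can be replaced by the all-carbon 2,5-dimethylphenyl, with 0 hydrogen-bond acceptors, and the two compounds stand level (a 1.2-fold lower number from compound 2 to compound 3 (0.09 log units; within the scatter)). Compared with the plain phenyl group, 2,5-dimethylphenyl gives the only step at this position that lies beyond the scatter, and it is a modest one (a 2.1-fold lower number from compound 1 to compound 3 (0.33 log units; beyond the scatter)). Nothing available explains why the numbers fall as they do, so these results describe what happens at this position but not the reason for it.

What each of the two methyl groups in 2,5-dimethylphenyl contributes on its own stays open, as the compounds shown carry either both or neither. Also open, going by these compounds, is how the number would respond to an amine or a carboxylic acid on this aromatic ring, or to a longer chain on the sulfonyl sulfur in place of the ring.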